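This account rests on a few compounds, and the source may have more. Where it says the series, first, only, none or still open, it means among the compounds named here.

Measured so far:
Compound 1 `COc1ccc(-c2nnc(SCC(=O)Nc3ccc(/C(C)=N/O)cc3)n2-c2ccccc2)cc1` — 57%
Compound 2 `CCn1c(SCC(=O)Nc2ccc(/C(C)=N/O)cc2)nnc1-c1ccccc1` — 65%
Compound 3 `COc1ccc(-c2nnc(SCC(=O)Nc3ccc(C(C)=O)cc3)n2-c2ccccc2)cc1` — 58%

In a functional assay on the whole organism (strain albino) for inhibition, with Rattus norvegicus as the target, read by paw edema, with stated times of 30 min and 3 h, at a dose of 0.28 mmol/kg by the oral route (on this read-out higher numbers stand for more inhibition at the one dose given (going by the name of the read-out) and lower numbers for less inhibition), compound 1 gives 57%. Compound 3 gives 58%, and the two differ by a group of 3 heavy atoms (2 carbon, 1 oxygen; no ring) in place of a group of 4 heavy atoms (2 carbon, 1 nitrogen, 1 oxygen; no ring), on an aromatic carbon. That change made a step of a number 1 percentage points higher from compound 1 to compound 3 (within the scatter), so the two values stand within the scatter of each other and show no real difference.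

Compound 2 gives 65%; its gaps to compound 3 and to compound 1 are both within the scatter, so no ordering among the three is claimed. How the core of compound 2 differs from the core of compound 1 is not broken down here.

Compound 4 `CCn1c(SCC(=O)Nc2ccc(C(C)=O)cc2)nnc1-c1ccccc1` is not yet measured. It differs from compound 2 by a group of 3 heavy atoms (2 carbon, 1 oxygen; no ring) in place of a group of 4 heavy atoms (2 carbon, 1 nitrogen, 1 oxygen; no ring), on an aromatic carbon, the same change as from compound 1 to compound 3. Because that earlier step was a number 1 percentage points higher from compound 1 to compound 3 (within the scatter), the step from compound 2 to compound 4 is expected to be of a similar size, a number 1 percentage points higher from compound 2 to compound 4 (within the scatter), resting only on this single earlier example. Compound 4 is therefore estimated to give 66%, expected between 55% and 76%.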

Compound 4, a percentage reported as inhibition, in the whole organism at one dose (the size of the read-out at that dose, not a potency): 56%
Beside the measured number, compound 4's estimate is 10 percentage points above it; the range from low to high includes it.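

In this assay, acetyl in place of the group of 4 heavy atoms on the aromatic carbon gives a step of a number 9 percentage points lower from compound 2 to compound 4 (within the scatter). Set beside the earlier step on the other core, this step shows no real difference between the two cores: the same change on two cores in this assay, a number 1 percentage points higher (within the scatter) from compound 1 to compound 3 and a number 9 percentage points lower (within the scatter) from compound 2 to compound 4, 10 percentage points apart, within the scatter of two such steps So far as these four compounds go, the change can be carried from one core to the other without a detectable difference, but neither step stands beyond the scatter, so the data show no real effect of the change on either core and cannot tell whether the two steps are truly alike or only too small to separate.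

The compounds shown leave open whether an amine or a carboxylic acid on that aromatic carbon would give a step beyond the scatter, and what a longer chain in place of the ethyl group of compound 4 would do. They also leave open whether the same change would hold on any core beyond these two, and at any dose other than the one given.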